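A few compounds are considered here, and "the series" means these few. Any claim that something is new, unique, unknown or untested is made for them only; others in the source may bear on it.

Compound 1, whose structure is `O=C(Nc1ccccc1)Nc1cccc(CNc2nccnc2Cl)c1`, is one of three closely related compounds tested in a functional assay on HepG2 cells (Homo sapiens) for antiproliferative activity, read by MTT assay, with a stated time of 48 h; on this read-out higher numbers stand for weaker inhibition and lower numbers for stronger inhibition. In this assay compound 1 gives 15600 nM, the highest of the three numbers, though its neighbours sit close: compound 3, with structure `Cc1ccccc1NC(=O)Nc1cccc(CNc2nccnc2Cl)c1`, gives 15300 nM, and compound 2, with structure `CCc1ccccc1NC(=O)Nc1cccc(CNc2nccnc2Cl)c1`, gives 7860 nM. Because the change a 1.0-fold lower number from compound 1 to compound 3 (0.01 log units; within the scatter) and the change a 2.0-fold lower number from compound 1 to compound 2 (0.30 log units; within the scatter) both stay inside the scatter, the three compounds cannot be ranked against one another on this read-out.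

Compound 4, whose structure is `O=C(Nc1cccc(CNc2nccnc2Cl)c1)Nc1ccc(Cl)cc1Br`, has not yet been measured. It differs from compound 1 at the phenyl that hangs from the amide-type nitrogen of the shared core: 2-bromo-4-chlorophenyl in place of phenyl on an amide-type nitrogen. The measured steps that bear on this are the two small additions to that same phenyl, a 2.0-fold lower number from compound 1 to compound 2 (0.30 log units; within the scatter) and a 1.0-fold lower number from compound 1 to compound 3 (0.01 log units; within the scatter), neither of which moved the number beyond the scatter. Two halogens on the same ring are a larger change than a methyl or an ethyl, but nothing measured here points in either direction. Compound 4 is therefore expected to land close to compound 1, with the step of a 1.4-fold lower number from compound 1 to compound 4 (0.15 log units; within the scatter) not exceeding the scatter, at an estimated 11000 nM, within a range of 4000 nM to 30000 nM.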

Compound 4, half-maximal inhibitory concentration: 6720 nM
Estimate against measurement, compound 4: 1.6-fold (0.21 log units) above, within the range that was stated.
By their numbers in this assay, from the lowest: compounds 4, 2, 3 and 1 (each within the scatter of the next, the first and the last beyond it).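

In this assay, going by these compounds alone, the place on the amide-type nitrogen now shows a step beyond the scatter for the first time: putting 2-bromo-4-chlorophenyl in place of phenyl gives a 2.3-fold lower number from compound 1 to compound 4 (0.37 log units; beyond the scatter) and putting it in place of 2-methylphenyl gives a 2.3-fold lower number from compound 3 to compound 4 (0.36 log units; beyond the scatter) so the number can be moved from this position, though only modestly. The comparison with 2-ethylphenyl is less clear, as the step of a 1.2-fold lower number from compound 2 to compound 4 (0.07 log units; within the scatter) stays within the scatter, which means these two groups cannot be told apart here and compound 4 cannot be called the most potent of the four. Nothing measured alongside these numbers offers an explanation for the step.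

Going by these compounds, because both halogens enter together, it remains open whether the step belongs to the bromine, the chlorine or the pair, a question that 2-bromophenyl and 4-chlorophenyl on their own could settle. Also open, on these data alone, is how groups of another kind would fare on this nitrogen, such as a pyridyl ring, a cyclohexyl ring or a phenyl carrying a carboxylic acid, and whether any of them would go beyond these modest steps.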